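Swapping a methoxypiperidine for a bicyclic carbon frame

A few compounds are considered here, and "the series" means these few. Any claim that something is new, unique, unknown or untested is made for them only; others in the source may bear on it.

The three measured compounds share one core, seen in compound 1 `O=C(C1CCC(F)(F)CC1)N1CC(c2nc(-c3cccc(Cl)c3)no2)C1`. In an assay on HEK293 cells for positive allosteric modulation of metabotropic glutamate receptor 5 (Homo sapiens), read by FLIPR (a higher number here means that more compound is needed for the effect, a lower number that less compound is needed), compound 1 gives 180 nM. Compound 2 `CC1CCN(C(=O)N2CC(c3nc(-c4cccc(Cl)c4)no3)C2)CC1`, which carries 4-methylpiperidin-1-yl on the carbonyl carbon, gives 865 nM in this assay, a change described as a 4.8-fold higher number from compound 1 to compound 2 (0.68 log units; beyond the scatter). Compound 3 `COC1CCN(C(=O)N2CC(c3nc(-c4cccc(Cl)c4)no3)C2)CC1` stands weakest of the three on the numbers shown. In this assay compound 3 reaches only > 10000 nM, which is a limit of the assay and not a number (the limit of > 10000 nM in this assay, at which 1 of the 3 values shown sits). Both steps toward it lie beyond the scatter: an at least 55-fold higher number from compound 1 to compound 3 (1.74 log units; beyond the scatter) and an at least 11-fold higher number from compound 2 to compound 3 (1.06 log units; beyond the scatter).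

Compound 4 `O=C([C@@H]1CC2CCC1C2)N1CC(c2nc(-c3cccc(Cl)c3)no2)C1` is not yet measured. It differs from compound 3 in one place: a group of 7 heavy atoms (7 carbon; 2 five-membered non-aromatic rings of carbon only) in place of a group of 8 heavy atoms (6 carbon, 1 nitrogen, 1 oxygen; one six-membered non-aromatic ring with 1 hetero atom), on a carbonyl carbon. The change removes the methoxy-bearing piperidine and puts a ring of carbon only on the carbonyl carbon, the direction that the large step of an at least 55-fold higher number from compound 1 to compound 3 (1.74 log units; beyond the scatter) took when read backwards, while the modest step of a 4.8-fold higher number from compound 1 to compound 2 (0.68 log units; beyond the scatter) shows a carbon-only ring also ahead of a methylated piperidine. A large drop in the number is therefore expected in this assay. Compound 4 is expected to give 350 nM, between 80 nM and 2500 nM, which is the step of an at least 28-fold lower number from compound 3 to compound 4 (1.45 log units; beyond the scatter).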

Compound 4, half-maximal effective concentration: 98 nM
Compound 4: middle estimate off by 3.6-fold (0.55 log units), on the high side, and the stated range covers the measured number.
By their numbers in this assay, from the lowest: compounds 4 and 1 (each within the scatter of the next); then compound 2. At a limit, above all of these: compound 3.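

Replacing 4-methoxypiperidin-1-yl with a carbon-only group of two five-membered rings on the carbonyl carbon gives an at least 100-fold lower number from compound 3 to compound 4 (2.00 log units; beyond the scatter) in this assay. The value of compound 3 in that step is a limit of the assay and not a number: the limit of > 10000 nM in this assay, at which 1 of the 4 values shown sits.

The new group also stands ahead of 4-methylpiperidin-1-yl, with an 8.8-fold lower number from compound 2 to compound 4 (0.95 log units; beyond the scatter), but it cannot be told apart from 4,4-difluorocyclohexyl, with a 1.8-fold lower number from compound 1 to compound 4 (0.26 log units; within the scatter), so two different carbon-only groups on this carbonyl carbon now sit level, and both sit ahead of the two piperidines shown.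

The compounds shown leave open whether the two-ring frame matters or whether a ring of carbon alone is enough, a question that a plain cyclohexyl or cyclopentyl group on the same carbonyl carbon would help to settle. They also leave open what the opposite arrangement at the defined stereocentre of the new group would give, and where an unsubstituted piperidine would fall relative to its methyl and methoxy relatives.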